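This account rests on a few compounds, and the source may have more. Where it says the series, first, only, none or still open, it means among the compounds named here.

Measured so far:
compound 1, `CNc1nc(Cl)nc(N[C@@H](C)c2ccccc2)n1`, 26900 nM
compound 2, `C[C@H](Nc1nc(Cl)nc(NC(C)(C)C)n1)c1ccccc1`, 7410 nM

In an ADME assay on the whole organism for inhibition, with Echinochloa crus-galli var. formosensis as the target, with a stated time of 4 days (a higher number here means a weaker inhibitor, a lower number a stronger inhibitor), compound 1 gives the highest of the two numbers; its nearest neighbour is compound 2 (a 3.6-fold lower number from compound 1 to compound 2 (0.56 log units; beyond the scatter)). Compound 3, `CCCN(C)c1nc(Cl)nc(N[C@@H](C)c2ccccc2)n1`, differs from compound 1 by propyl in place of hydrogen on a nitrogen on an aromatic ring. Going by the values given here, that single measured step shows that more carbon on this same nitrogen went with a lower number, so a further drop is expected, though a nitrogen carrying two carbon groups instead of one has no direct precedent here. For compound 3 the expected result is 14000 nM, within 5000 nM to 45000 nM, amounting to an estimated 1.9-fold lower number from compound 1 to compound 3 (0.28 log units; within the scatter).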

Compound 3, half-maximal inhibitory concentration: 380 nM
For compound 3 the middle estimate is 37-fold (1.57 log units) above the measured one; measured number below the stated range.
By their numbers in this assay, from the lowest: compound 3; then compound 2; then compound 1.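

In this assay, adding propyl to the nitrogen that already carries methyl has a large effect (a 71-fold lower number from compound 1 to compound 3 (1.85 log units; beyond the scatter)), well beyond the earlier change from methyl to tert-butyl on that nitrogen (a 3.6-fold lower number from compound 1 to compound 2 (0.56 log units; beyond the scatter)). Methyl(propyl)amino also outdoes (tert-butyl)amino at this same place (a 20-fold lower number from compound 2 to compound 3 (1.29 log units; beyond the scatter)). No measurement shown gives a reason for this gain.

As far as these compounds go, whether the gain comes from losing the hydrogen on this nitrogen or from the propyl chain itself stays open. From the compounds shown here alone, how dimethylamino, a longer chain such as butyl, or piperidine would fare at this place also stays open.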